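Replacing 4-fluorophenyl with pyridin-3-yl on a shared core

This account rests on a few compounds, and the source may have more. Where it says the series, first, only, none or still open, it means among the compounds named here.

Of the compounds shown here, three sharing one core have been measured in a functional assay on HT-29 cells (Homo sapiens) for inhibition, with a stated time of 72 h; a lower number here means a stronger inhibitor, a higher number a weaker inhibitor. Compound 1 (`COc1ccc(S(=O)(=O)N2CCc3cccc(-c4ccc(F)c(F)c4)c32)cc1`) gives 57 nM, compound 2 (`COc1ccc(S(=O)(=O)N2CCc3cccc(-c4ccc(N(C)C)cc4)c32)cc1`) gives 467 nM, and compound 3 (`COc1ccc(S(=O)(=O)N2CCc3cccc(-c4ccc(F)cc4)c32)cc1`) gives 85.5 nM. Compound 3 cannot be told apart from compound 1, as the data show a 1.5-fold higher number from compound 1 to compound 3 (0.18 log units; within the scatter). Compound 2 stands clearly apart from it, with a 5.5-fold lower number from compound 2 to compound 3 (0.74 log units; beyond the scatter).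

The unmeasured compound 4 (`COc1ccc(S(=O)(=O)N2CCc3cccc(-c4cccnc4)c32)cc1`) carries pyridin-3-yl in place of 4-fluorophenyl on an aromatic carbon. Among the measured compounds shown here, no measured compound has a ring with a hetero atom at this place, so the evidence is indirect. Removing one fluoro changed little, but compound 2 shows that replacing the whole group can matter, with an 8.2-fold higher number from compound 1 to compound 2 (0.91 log units; beyond the scatter). A rise in this assay smaller than that one therefore seems likely. What is expected is a 2.3-fold higher number from compound 3 to compound 4 (0.37 log units; beyond the scatter), a modest step with real uncertainty. For compound 4 the estimated value is 200 nM, with an expected range from 70 nM to 600 nM.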

Compound 4, half-maximal inhibitory concentration: 76.3 nM
Beside the measured number, compound 4's estimate is 2.6-fold (0.42 log units) above it, and the stated range covers the measured number.
By their numbers in this assay, from the lowest: compounds 1, 4 and 3 (each within the scatter of the next); then compound 2.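

Among the compounds shown here, until this result, no compound had a ring with a hetero atom at this place, and in this assay putting pyridin-3-yl in place of 4-fluorophenyl gives a 1.1-fold lower number from compound 3 to compound 4 (0.05 log units; within the scatter) and so leaves the read-out unchanged within the scatter. The comparison with the 3,4-difluorophenyl of compound 1 gives a 1.3-fold higher number from compound 1 to compound 4 (0.13 log units; within the scatter) and the comparison with the 4-(dimethylamino)phenyl of compound 2 gives a 6.1-fold lower number from compound 2 to compound 4 (0.79 log units; beyond the scatter) and thus shows that a ring without fluorine can match the fluorinated rings here, while compound 2 remains set apart. No measurement at hand explains why these rings behave alike.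

Pyridin-3-yl is the only ring with a hetero atom shown, so pyridin-4-yl, pyrimidin-5-yl and thiophen-3-yl remain open. Also open, as far as these compounds go, is how a phenyl ring carrying a carboxylic acid or a morpholine would compare with compound 2.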